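Swapping the Stilbene Arm for a Trifluoromethoxyphenyl Ring

The source may hold more compounds than are shown below. What is called first, only, known or untested is meant among the compounds shown, and "the series" means these compounds.

Measured compounds:
- Compound 1 `COC(=O)/C=C/c1cccc(N(Cc2ccc(/C=C/c3ccccc3F)cc2)C(=O)C2CCCCC2)c1`: 64 nM
- Compound 2 `COC(=O)/C=C/c1cccc(N(Cc2ccc(/C=C/c3c(C)cc(C)cc3C)cc2)C(=O)C(C)C)c1`: 149 nM
- Compound 3 `COC(=O)/C=C/c1cccc(N(Cc2ccc(/C=C/c3c(C)cc(C)cc3C)cc2)C(=O)NC(C)C)c1`: 431 nM

In an assay on isolated protein with Bile acid receptor (Homo sapiens) as the target (on this read-out lower numbers stand for an effect already at smaller amounts and higher numbers for an effect only at larger amounts of compound), compound 2 gives 149 nM, the second highest of the three numbers. Compound 1 gives 64 nM, a lower number, and compound 3 gives 431 nM, a higher one. Within the data shown here, the only single-point step known here, a 2.9-fold higher number from compound 2 to compound 3 (0.46 log units; beyond the scatter), concerns the carbonyl side of the shared core and says nothing about the other arm.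

Compound 4 `COC(=O)/C=C/c1cccc(N(Cc2ccc(-c3ccc(OC(F)(F)F)cc3)cc2)C(=O)C(C)C)c1` changes that other arm: 4-(trifluoromethoxy)phenyl in place of 2-(2,4,6-trimethylphenyl)ethenyl on an aromatic carbon. Compound 1 differs from compound 2 in two places at once, so its lower number cannot be attributed to the aryl arm alone. Among the measured compounds shown here, no measured step therefore bears directly on this change, and the expectation rests on little more than the spread of the known values. A modest shift toward higher numbers is expected, a 1.7-fold higher number from compound 2 to compound 4 (0.22 log units; within the scatter), with a wide range. Compound 4 is estimated at 250 nM, between 60 nM and 1000 nM.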

Compound 4, half-maximal effective concentration: 219 nM
The estimate for compound 4 lay 1.1-fold (0.06 log units) above the measured number, within the range that was stated.
By their numbers in this assay, from the lowest: compound 1; then compounds 2, 4 and 3 (each within the scatter of the next, the first and the last beyond it).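

Among these compounds, the first change in one place on this arm gives, in this assay, a 1.5-fold higher number from compound 2 to compound 4 (0.17 log units; within the scatter) and so leaves the two compounds indistinguishable on this read-out. Within this pair, a number in this range therefore does not depend on the 2-(2,4,6-trimethylphenyl)ethenyl group or its double bond outside aromatic rings, since 4-(trifluoromethoxy)phenyl, with the same count of heavy atoms, can stand in its place. No supporting measurement explains why these two different arms read alike.

The compounds shown do not tell whether a plain phenyl ring, or a carboxylic acid in place of the methyl ester, would also read alike. Among the compounds shown here, this swap is also seen only with the isopropyl group on the carbonyl, so its effect alongside the cyclohexyl or isopropylamino group remains open.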